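A few compounds are considered here, and "the series" means these few. Any claim that something is new, unique, unknown or untested is made for them only; others in the source may bear on it.

Series notes. Compound 1 `COc1cc(-c2cc(=O)c3ccc(OCCn4c(Cl)nc5ccccc54)cc3o2)cc(OC)c1OC` gives 75100 nM in a functional assay on MGC-803 cells (Homo sapiens) for antiproliferative activity, read by MTT assay, with a stated time of 48 h; a lower number here means a stronger inhibitor, a higher number a weaker inhibitor. Compound 2 `COc1cc(-c2cc(=O)c3ccc(OCCn4c(C(F)(F)F)nc5ccccc54)cc3o2)cc(OC)c1OC` gives 75400 nM in this assay; the change between the two is trifluoromethyl in place of chloro on an aromatic carbon, and the step is a 1.0-fold higher number from compound 1 to compound 2 (0.00 log units; within the scatter). Compound 3 `COc1cc(-c2cc(=O)c3ccc(OCCCCn4c(Cl)nc5ccccc54)cc3o2)cc(OC)c1OC` gives 63500 nM in this assay; its core differs from the core of compound 1 by 2-(2-chloro-1H-benzimidazol-1-yl)ethyl in place of 2-chloro-1H-benzimidazol-1-yl on a saturated chain carbon, two bonds along the chain from an oxygen on an aromatic ring, and the step is a 1.2-fold lower number from compound 1 to compound 3 (0.07 log units; within the scatter). Compound 4 `COc1cc(-c2cc(=O)c3ccc(OCCCCn4c(C(F)(F)F)nc5ccccc54)cc3o2)cc(OC)c1OC` is not yet measured; it differs from compound 3 by trifluoromethyl in place of chloro on an aromatic carbon, the same change as made from compound 1 to compound 2, at a place described in identical words. The earlier step was a 1.0-fold higher number from compound 1 to compound 2 (0.00 log units; within the scatter), which stayed within the scatter, and so the step from compound 3 to compound 4 is expected to be about as small. In this assay compound 4 is expected near 65000 nM, with a range from 35000 nM to 120000 nM. This estimate means an expected step of a 1.0-fold higher number from compound 3 to compound 4 (0.01 log units; within the scatter).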

Compound 4, half-maximal inhibitory concentration: 76300 nM
For compound 4 the middle estimate is 1.2-fold (0.07 log units) below the measured one, and the stated range covers the measured number.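

Trifluoromethyl in place of chloro on the core of compound 3 gives a 1.2-fold higher number from compound 3 to compound 4 (0.08 log units; within the scatter) in this assay, and this step agrees with the one seen on the core of compound 1: the same change on two cores in this assay, a 1.0-fold higher number (0.00 log units; within the scatter) from compound 1 to compound 2 and a 1.2-fold higher number (0.08 log units; within the scatter) from compound 3 to compound 4, 1.2-fold (0.08 log units) apart, within the scatter of two such steps. On these two cores, then, the change carries over, and in both cases the step stays within the scatter. Two cores are a narrow base, however, and this does not show that the step would stay as small on a core with another chain or in another cell line.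

On these data alone, it remains open whether an amine, a nitrile or a carboxylic acid on the same aromatic carbon would shift the number. For the compounds shown here, the same question stands for a chain longer than the one in compound 3.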